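Cytotoxicity notes on a fused bicyclic amide series

The source may report more compounds than this note shows. Statements on the series, on what has been measured and on what is new or still open speak of the compounds shown alone.

Measured compounds:
- compound 1, `O=C(Nc1ccc(F)c(-c2nc3ncc(-c4cncc(F)c4)cc3[nH]2)c1)N1CCCC1`: > 50000 nM
- compound 2, `Cc1nc(C)c(C(=O)Nc2ccc(F)c(-c3nc4ncc(-c5ccccc5Cl)cn4n3)c2)o1`: > 50000 nM

Both measured values come from an ADME assay on HepG2 cells (Homo sapiens) for cytotoxicity, read by resazurin assay, with a stated time of 48 h; a higher number here means that more compound is needed for the effect, a lower number that less compound is needed. For compound 1 the value > 50000 nM is a limit of the assay, not a number. For compound 2 the value > 50000 nM is likewise a limit. For the measured compounds named here, compound 1 therefore stands at the limit, together with the one other value shown, as summarised in the limit of > 50000 nM in this assay, at which 2 of the 2 values shown sit. Going by the values given here, no step between two measured compounds can be given, since no pair differs in one place only.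

Compound 3, `O=C(Nc1ccc(F)c(-c2nc3ncc(-c4ccc(O)cc4)cc3[nH]2)c1)N1CCCC1`, is the next compound to be measured in this assay. It differs from compound 1 as follows: 4-hydroxyphenyl in place of 5-fluoropyridin-3-yl on an aromatic carbon. Among the compounds with values here, since both measured compounds sit at the limit, there is no measured step on which to size the change; the expectation is that compound 3 stays at or near the limit, with no step beyond the scatter.

Compound 3 is thus expected to give 50000 nM, with a range from 20000 nM to 120000 nM. The estimated step of a number no higher from compound 1 to compound 3 (the limit leaves the size open) is expected to be none beyond the scatter.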

Compound 3, half-maximal effective concentration: > 50000 nM
Compound 3: no number, only a limit; the forecaster's own chance of this, stated with the estimate: 75%; the middle value sits exactly at the limit.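

No step from compound 1 to compound 3 can be read in this assay, since each value is a limit and not a number: the limit of > 50000 nM in this assay, at which 3 of the 3 values shown sit.

The compounds shown leave open what number, if any, each of compound 1, compound 2 and compound 3 would reach, and whether any change on the shared core gives a readable value.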